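A few compounds are considered here, and "the series" means these few. Any claim that something is new, unique, unknown or untested is made for them only; others in the source may bear on it.

Three compounds share one core and differ only in the link between the two aromatic rings. Compound 1 `O=C1COC(c2ccc(NC(=O)Nc3cccc(Cl)c3)cc2)=NN1` carries a urea link and in an assay on cells for inhibition of Amine oxidase [flavin-containing] B (Homo sapiens), read by Amplex Red, with a stated time of 30 min (on this read-out higher numbers stand for weaker inhibition and lower numbers for stronger inhibition), compound 1 gives 2890 nM. Compound 2 `O=C1COC(c2ccc(NCc3cccc(Cl)c3)cc2)=NN1` carries an aminomethyl link, and in this assay compound 2 gives 2690 nM. Compound 3 `O=C1COC(c2ccc(/N=N/c3cccc(Cl)c3)cc2)=NN1` carries an azo link, and in this assay compound 3 gives 287 nM, the lowest of the three numbers and well beyond the scatter from either neighbour.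

Compound 4 `Cc1cccc(/N=N/c2ccc(C3=NNC(=O)CO3)cc2)c1` keeps the azo link and changes one substituent: methyl in place of chloro on an aromatic carbon. Among the compounds with values here, no measured pair shows this swap, so the step is expected to be small, slightly toward weaker inhibition or none beyond the scatter, as a 1.6-fold higher number from compound 3 to compound 4 (0.20 log units; within the scatter). Compound 4 is therefore expected to give about 450 nM, between 150 nM and 1400 nM.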

Compound 4, half-maximal inhibitory concentration: 25 nM
Estimate against measurement, compound 4: 18-fold (1.26 log units) above, and the stated range ends above it.
By their numbers in this assay, from the lowest: compound 4; then compound 3; then compounds 2 and 1 (each within the scatter of the next).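

With the azo link kept, swapping one heavy atom on the aromatic ring, 3-chlorophenyl to 3-methylphenyl, gives an 11-fold lower number from compound 3 to compound 4 (1.06 log units; beyond the scatter) in this assay and so moves the number beyond the scatter. Within the data shown here, the earlier compounds differed only in the link, so this is the first view of how much this substituent alone can matter. Nothing measured here explains the size of this step. On these data alone, whether an amine, a methoxy group or an ethyl group at this place would lower the number further remains open. So does whether methyl would act the same way with the urea or aminomethyl link.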